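This account rests on a few compounds, and the source may have more. Where it says the series, first, only, none or still open, it means among the compounds named here.

Measured so far:
compound 1 `O=C(Nc1cccc(-n2cc(-c3ccncc3)c(-c3cc(O)cc(Cl)c3)n2)c1)Nc1ccc(Cl)c(Cl)c1` — -38%
compound 2 `COc1cc(Cl)cc(-c2nn(-c3cccc(NC(=O)Nc4ccc(Cl)c(Cl)c4)c3)cc2-c2ccncc2)c1` — -9%

In a functional assay on OVCAR-8 cells (Homo sapiens) for inhibition, read by sulforhodamine B assay, with a stated time of 48 h, tested at 100 uM (a lower number here means a stronger effect, a higher number a weaker effect of the compound at the concentration tested), compound 2 gives -9%, the highest of the two numbers shown; the nearest is compound 1 with -38%, and the only measured step, a number 29 percentage points higher from compound 1 to compound 2 (beyond the scatter), concerns a methyl in place of hydrogen on an oxygen on an aromatic ring. Compound 3 `COc1cc(Cl)cc(-c2nn(-c3cccc(NC(=O)c4cccc(C(F)(F)F)c4)c3)cc2-c2ccncc2)c1` differs from compound 2 elsewhere: 3-(trifluoromethyl)phenyl in place of (3,4-dichlorophenyl)amino on a carbonyl carbon. Within the data shown here, no measured step bears on this change, so no direction can be read from the series and the expected step of a number 1 percentage points lower from compound 2 to compound 3 (within the scatter) is set near zero, with a wide range. Compound 3 is estimated at -10%, between -45% and 25%.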

Compound 3, a percentage reported as activity, at one concentration (the size of the read-out at that concentration, not a potency): 41%
The estimate for compound 3 lay 51 percentage points below the measured number; measured number outside the range, above it.
By their numbers in this assay, from the lowest: compound 1; then compound 2; then compound 3.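

In this assay, the carbonyl-carbon position, which the earlier pair left unchanged, carries a large step: a number 50 percentage points higher from compound 2 to compound 3 (beyond the scatter). With 3-(trifluoromethyl)phenyl in place of (3,4-dichlorophenyl)amino, the sign of the read-out reverses, from -9% for compound 2 to 41% for compound 3, so the effect at this concentration depends strongly on this group. No available evidence accounts for the step. The change swaps the ring substituents and removes the amino nitrogen together, so the two contributions remain unseparated. A (3-(trifluoromethyl)phenyl)amino group on the same carbonyl carbon would separate them.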